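Propyl in place of phenyl on a saturated ring carbon

The source may hold more compounds than are shown below. What is called first, only, known or untested is meant among the compounds shown, and "the series" means these compounds.

In a physicochemical assay for lipophilicity, measured as octanol-water partition (a higher number here means a more lipophilic compound, a lower number a more polar compound), compound 1 (`CC1=C(C(=O)OCc2cccnc2)C(c2cccc(O)c2)C2=C(CCCC2=O)N1`) gives 1.21 and compound 3 (`CC1=C(C(=O)OCc2ccccn2)C(c2ccc([N+](=O)[O-])cc2)C2=C(CCCC2=O)N1`) gives 1.88 on the same scale. Compound 2 (`CC1=C(C(=O)OCc2cccnc2)C(c2ccccc2)C2=C(CCCC2=O)N1`) reads 2.35 and stands highest of the three, with both others lower by more than the scatter. Compound 4 (`CCCC1C(C(=O)OCc2cccnc2)=C(C)NC2=C1C(=O)CCC2`) is still unmeasured and differs from compound 2 at one place (propyl in place of phenyl on a saturated ring carbon) with propyl in place of phenyl on a saturated ring carbon. Within the data shown here, the one measured step with a single change is a number 1.14 log units higher from compound 1 to compound 2 (beyond the scatter) and it is large, but it concerns hydrogen in place of hydroxy on an aromatic carbon and leaves the phenyl itself in place. Among the measured compounds shown here, no measured step replaces phenyl with a chain, so that large step sets no size here, and the expectation rests on the structural change alone. The estimated step is a number 0.35 log units lower from compound 2 to compound 4 (beyond the scatter) and it is expected to be a modest fall. Compound 4 is estimated at 2 with an expected range from 1.6 to 2.4 in this assay for now.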

Compound 4, partition coefficient: 2.23
Compound 4: the middle estimate sits 0.23 log units below what was measured; the range from low to high includes it.
By their numbers in this assay, from the lowest: compound 1; then compound 3; then compounds 4 and 2 (each within the scatter of the next).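

In this assay, among these compounds, the saturated ring carbon now carries something other than an aromatic ring for the first time, and replacing phenyl with propyl gives a number 0.12 log units lower from compound 2 to compound 4 (within the scatter), so the shorter chain cannot be told apart from phenyl here. Against the hydroxy-bearing ring, the same position shows a number 1.02 log units higher from compound 1 to compound 4 (beyond the scatter), which is large, as is a number 1.14 log units higher from compound 1 to compound 2 (beyond the scatter), the step that removes only the hydroxy. No measurement offered here gives a reason for these readings.

The compounds shown leave open how a longer chain such as hexyl, or a propyl chain ending in an amine or a carboxylic acid, would read at this carbon. They also leave open whether propyl in place of phenyl would give so small a step with the ester carried by compound 3.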